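Three Low-Stability Sulfones and an Untested Pyridinone Analogue

The source may hold more compounds than are shown below. What is called first, only, known or untested is meant among the compounds shown, and "the series" means these compounds.

The series shares one core carrying a sulfonyl-linked biaryl arm. Compound 1 `CCCCc1nc(=O)c(S(=O)(=O)c2ccc(-c3ccc(F)cc3)cc2)c(O)n1-c1c(OC)cccc1OC` bears a 4-fluorophenyl on that arm, compound 2 `CCCCc1nc(=O)c(S(=O)(=O)c2ccc(-c3cccnc3)cc2)c(O)n1-c1c(OC)cccc1OC` a pyridin-3-yl, and compound 3 `CCCCc1nc(=O)c(S(=O)(=O)c2ccc(-c3ccc(F)nc3)cc2)c(O)n1-c1c(OC)cccc1OC` a 6-fluoropyridin-3-yl. In an ADME assay on microsomes from liver (Rattus norvegicus) for metabolic stability, using NADPH, with a stated time of 10 min (on this read-out higher numbers stand for a more stable compound and lower numbers for a less stable compound), compound 1 gives 5%, compound 2 gives 3%, and compound 3 gives 2%. Compound 2 thus sits among three numbers that all lie close to one another, with compound 1 at 5% and compound 3 at 2% on either side of it.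

The steps that connect these compounds are small: a number 2 percentage points lower from compound 1 to compound 2 (within the scatter), a number 3 percentage points lower from compound 1 to compound 3 (within the scatter) and a number 1 percentage points lower from compound 2 to compound 3 (within the scatter). None of them moves the read-out beyond its scatter, so swapping the aryl group at this position has so far left the outcome in this assay unchanged.

Compound 4 `CCCCc1nc(=O)c(S(=O)(=O)c2ccc(-n3ccccc3=O)cc2)c(O)n1-c1c(OC)cccc1OC` is the next member. Relative to compound 2 the change is a group of 7 heavy atoms (5 carbon, 1 nitrogen, 1 oxygen; one six-membered aromatic ring with 1 hetero atom) in place of a group of 6 heavy atoms (5 carbon, 1 nitrogen; one six-membered aromatic ring with 1 hetero atom), on an aromatic carbon. As the earlier changes on this same aromatic carbon produced only a number 2 percentage points lower from compound 1 to compound 2 (within the scatter) and a number 1 percentage points lower from compound 2 to compound 3 (within the scatter), the step of a number 1 percentage points higher from compound 2 to compound 4 (within the scatter) is expected to remain within the scatter as well. Compound 4 is therefore estimated to give 4% in this assay, with a range from 1% to 12%.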

Compound 4, percent of the compound remaining: 83%
Beside the measured number, compound 4's estimate is 79 percentage points below it; measured number above the stated range.
By their numbers in this assay, from the lowest: compounds 3, 2 and 1 (each within the scatter of the next); then compound 4.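

In this assay, this aromatic carbon, para to a large group, turns out not to be indifferent to what it carries: the three earlier aryl groups stayed within the scatter of one another, whereas the new group gives a number 80 percentage points higher from compound 2 to compound 4 (beyond the scatter), a number 81 percentage points higher from compound 3 to compound 4 (beyond the scatter) and a number 78 percentage points higher from compound 1 to compound 4 (beyond the scatter). The change therefore does not depend on a six-membered aromatic ring with 1 hetero atom alone, since compound 2 and compound 3 carry such a ring as well, and what sets the entering group apart from pyridin-3-yl is its oxygen and its double bond outside aromatic rings. Nothing available here bears on why this single change separates compound 4 so sharply from the other three.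

The compounds shown leave open whether the oxygen as a carbonyl is what matters, or whether a methoxy group, an amine or a carboxylic acid on the same ring, or a non-aromatic ring such as morpholine, would give a similar number. They also leave open whether the step would hold with a different chain in place of the butyl chain on the shared core.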